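Chlorine to Fluorine on the Pendant Ring

The source may hold more compounds than are shown below. What is called first, only, known or untested is meant among the compounds shown, and "the series" means these compounds.

Three compounds have been tested in an ADME assay on MT4 cells (Homo sapiens) for cytotoxicity, read by MTT assay, with a stated time of 4 days; a higher number here means that more compound is tolerated, a lower number that less compound is tolerated:
Compound 1, `Cc1cc(-c2cccc(C#N)c2)cc(C)c1Nc1ccnc(Nc2ccc(C#N)cc2)n1`, gives 920 nM.
Compound 2, `Cc1cc(-c2cccc(Cl)c2)cc(C)c1Nc1ccnc(Nc2ccc(C#N)cc2)n1`, gives 2160 nM.
Compound 3, `Cc1cc(-c2ccccc2Cl)cc(C)c1Nc1ccnc(Nc2ccc(C#N)cc2)n1`, gives 3990 nM.

Compound 3 has the highest number of the three, so the most compound is tolerated there. Its gap to compound 2 is within the scatter, while its gap to compound 1 is beyond it, as a 4.3-fold higher number from compound 1 to compound 3 (0.64 log units; beyond the scatter) shows. Compound 4, `Cc1cc(-c2ccccc2F)cc(C)c1Nc1ccnc(Nc2ccc(C#N)cc2)n1`, differs from compound 3 in a single way: fluoro in place of chloro on an aromatic carbon. Among the measured compounds shown here, none of the measured steps exchanges one halogen for another. The closest guides are a 2.3-fold higher number from compound 1 to compound 2 (0.37 log units; beyond the scatter), where a chloro replaces a cyano, and a 1.8-fold higher number from compound 2 to compound 3 (0.27 log units; within the scatter), where the chloro sits on a different carbon of the same ring. One is modest and the other within the scatter, and a change of halogen at an unchanged place is taken as smaller still. Compound 4 is therefore expected to stay close to compound 3 in this assay, with no step beyond the scatter. The expected step is a 1.2-fold lower number from compound 3 to compound 4 (0.10 log units; within the scatter). The estimate for compound 4 is 3200 nM, within 1300 nM to 8000 nM.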

Compound 4, half-maximal cytotoxic concentration: 2120 nM
Estimate against measurement, compound 4: 1.5-fold (0.18 log units) above; the range from low to high includes it.
By their numbers in this assay, from the lowest: compound 1; then compounds 4, 2 and 3 (each within the scatter of the next).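

Fluoro in place of chloro, on an aromatic carbon ortho to a large group, is the first exchange of one halogen for another seen in this assay, and the step stays within the scatter (a 1.9-fold lower number from compound 3 to compound 4 (0.27 log units; within the scatter)). Compound 4 also cannot be told apart from the 3-chlorophenyl compound (a 1.0-fold lower number from compound 2 to compound 4 (0.01 log units; within the scatter)), while it remains separated from the 3-cyanophenyl compound by a step beyond the scatter (a 2.3-fold higher number from compound 1 to compound 4 (0.36 log units; beyond the scatter)), so all three halogen-bearing compounds shown lie beyond the scatter from compound 1. Nothing measured here explains why the numbers fall as they do.

Still open, from the compounds shown here alone, is whether a bromo, a methyl or an amine at this same place would also stay within the scatter of compound 3. A carboxylic acid there would be a much larger change, and its effect cannot be judged from these four compounds.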